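The compounds below may be only part of what the source reports. "The series", "measured", "known", "first", "only" and "open" are said of these compounds alone.

Of the compounds shown here, three built on one shared core have been measured in an in vitro functional assay on SH-EP1 cells for agonist activity at Neuronal acetylcholine receptor; alpha4/beta2 (Homo sapiens), read by FLIPR and calcium flux; on this read-out higher numbers stand for larger maximal responses and lower numbers for smaller maximal responses. Compound 1 `CN1C[C@H]2C=C(c3cccnc3)C[C@H](C2)C1` carries a methyl group on the amine nitrogen in its ring and gives 19%. For the measured compounds named here, compound 2 `C1=C(c2cccnc2)C[C@H]2CNC[C@@H]1C2` carries a hydrogen in that place and gives 114%; the step of a number 95 percentage points higher from compound 1 to compound 2 (beyond the scatter) is the only change of a single feature among the measured compounds. Compound 3 `C1=C(c2cncnc2)CC2CNCC1C2`, which carries a different attached ring and is drawn without configuration, gives 116%. On the numbers shown, compound 2 stands second highest of three, with compound 3 within the scatter of it and compound 1 far below it.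

Going by the values given here, compound 4 `C1=C(c2cccnc2)C[C@@H]2CNC[C@H]1C2` is the next compound to be measured. the two compounds have the same atoms and bonds and differ only in configuration as drawn: 2 of 2 stereo elements differ (all stereocentres are inverted: mirror images); a stereocentre at a saturated ring carbon is drawn S in compound 2 and R in compound 4; a stereocentre at a saturated ring carbon is drawn R in compound 2 and S in compound 4 The single measured step, from compound 1 to compound 2, concerns a methyl group against a hydrogen and says nothing about inverting configuration, so no measured step bears directly on this change. Mirror images can behave alike or very differently in this kind of cell assay, and the data give no guide to which will happen here. Compound 4 is therefore expected to give 70%, with a wide range from 10% to 120%. The expected step of a number 44 percentage points lower from compound 2 to compound 4 (beyond the scatter) points downward, but the uncertainty is large.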

Compound 4, largest response reached (reported as percent of maximum), in percent of the reference or control that the assay uses: 111%
The estimate for compound 4 lay 41 percentage points below the measured number; low and high end bracket the measured number.
By their numbers in this assay, from the lowest: compound 1; then compounds 4, 2 and 3 (each within the scatter of the next).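

In this assay, inverting both stereocentres gives a number 3 percentage points lower from compound 2 to compound 4 (within the scatter), so the two mirror images cannot be told apart on this read-out. For the compounds shown here, the earlier compounds showed only that swapping a methyl group for a hydrogen on the ring amine nitrogen matters a great deal; they could not show whether the configuration drawn on the shared core matters as well, and for this pair, with a hydrogen on that nitrogen, it makes no difference beyond the scatter. This reading is a clean one, as a single kind of change separates the pair: the fact that compounds 2 and 4 differ only in the configuration as drawn.

On these data alone, what remains open is whether mirror images would also match when the ring amine nitrogen carries a methyl group, as in compound 1, or a larger group such as an ethyl or a benzyl group. The read-out reports only the largest response reached, so it also leaves open whether compound 2 and compound 4 need similar concentrations to reach that response, and whether they behave alike at other receptors.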